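The source may report more compounds than this note shows. Statements on the series, on what has been measured and on what is new or still open speak of the compounds shown alone.

Compound 1 `CNC(=O)c1cc(C(=O)N[C@H]2[C@@H]3COC[C@@H]32)cc2c1OC[C@H]2c1ccccc1`: 3.3
Compound 2 `CNC(=O)c1cc(C(=O)N[C@H]2[C@@H]3COC[C@@H]32)cc2c1O[C@H](CF)[C@H]2c1ccccc1`: 3.6
Compound 3 `CNC(=O)c1cc(C(=O)NCCC[C@H]2OC[C@H](N)CO2)cc2c1OC[C@H]2c1ccccc1`: 2.6

In a physicochemical assay for lipophilicity, at pH 7.4 (a lower number here means a more polar compound, a higher number a more lipophilic compound), compound 2 gives 3.6 and is not separated from the core of compound 1: a number 0.30 log units higher from compound 1 to compound 2 (within the scatter). The next change leads to compound 4 `CNC(=O)c1cc(C(=O)NC)c2c(c1)[C@H](c1ccccc1)[C@@H](CF)O2`: one carbon atom in place of a group of 6 heavy atoms (5 carbon, 1 oxygen; one three-membered non-aromatic ring of carbon only, one five-membered non-aromatic ring with 1 hetero atom), on an amide-type nitrogen. Methyl enters on the amide-type nitrogen, while fluoromethyl stays, so the fluoromethyl step does not bear directly. One measured step removes the same group: a number 0.70 log units lower from compound 1 to compound 3 (beyond the scatter). Within the data shown here, it brings in a different group, and no measured compound carries methyl there, so it is only a loose guide to direction. A small downward step is expected, hardly clear of the scatter. The expected step is a number 0.30 log units lower from compound 2 to compound 4 (within the scatter). For compound 4 the estimated value is 3.3, with an expected range of 2.8 to 3.8.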

Compound 4, distribution coefficient: 3.3
The estimate for compound 4 equals the measured number at the digits printed; measured number inside the range.
By their numbers in this assay, from the lowest: compound 3; then compounds 1, 4 and 2 (each within the scatter of the next).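

In this assay, methyl on the amide-type nitrogen in place of the group of 6 heavy atoms, with fluoromethyl kept, stays within the scatter (a number 0.30 log units lower from compound 2 to compound 4 (within the scatter)). Among these compounds, this is the first reading for methyl at this position, and it contrasts with the step to the different group of compound 3 (a number 0.70 log units lower from compound 1 to compound 3 (beyond the scatter)), which lies beyond the scatter. No measurement at hand explains this result.

Open, from the compounds shown here alone, is how a carboxylic acid or an ethyl group on this nitrogen would read. Also open, going by these compounds, is whether the methyl exchange gives a similar step without fluoromethyl.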